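A few compounds are considered here, and "the series" means these few. Any claim that something is new, unique, unknown or untested is made for them only; others in the source may bear on it.

Measured compounds:
compound 1, `Cc1ccc(NS(=O)(=O)c2ccc(NC(=O)c3ccc(Cl)cc3Cl)cc2)cc1`
compound 2, `Cc1ccccc1NS(=O)(=O)c1ccc(NC(=O)c2ccc(Cl)cc2Cl)cc1`
compound 3, `O=C(Nc1ccc(S(=O)(=O)NCc2ccccc2)cc1)c1ccc(Cl)cc1Cl`

In a functional assay on HEK293 cells for agonist activity at probable G-protein coupled receptor 27 (Homo sapiens), read by a luciferase reporter and beta-arrestin recruitment, with a stated time of 10 min (a higher number here means that more compound is needed for the effect, a lower number that less compound is needed), compound 2 gives 1230 nM. Compound 1 reaches only the limit of the assay, > 100000 nM. Compound 3 likewise reaches only a limit, > 100000 nM, so its place among the numbers is known only as that limit, which two of the three values share (the limit of > 100000 nM in this assay, at which 2 of the 3 values shown sit). Compound 4, `O=C(NS(=O)(=O)c1ccc(NC(=O)c2ccc(Cl)cc2Cl)cc1)c1ccccc1`, differs from compound 3 by benzoyl in place of benzyl on a sulfonamide nitrogen. The measured steps that touch this same place are an at least 81-fold higher number from compound 2 to compound 3 (1.91 log units; beyond the scatter), a large one, and a step that the two limits leave unreadable from compound 1 to compound 3, which the two limits leave unreadable. Going by the values given here, no measured step shows a benzoyl group here, so the direction of the step is open. Compound 4 is estimated at 100000 nM, within 10000 nM to 300000 nM, that is, an expected step of a number no higher from compound 3 to compound 4 (the limit leaves the size open).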

Compound 4, half-maximal effective concentration: > 100000 nM
Compound 4: a limit, no number; the forecaster's own chance of this, stated with the estimate: 70%; the middle value lies on the limit itself.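

In this assay, compound 4 also gives only a limit, so a benzoyl group on the sulfonamide nitrogen joins benzyl and 4-methylphenyl there: the limit of > 100000 nM in this assay, at which 3 of the 4 values shown sit. The 2-methylphenyl group of compound 2 is still the only one shown here that gives a number, and the comparison with it can be read as an at least 81-fold higher number from compound 2 to compound 4 (1.91 log units; beyond the scatter). The steps from compound 1 and compound 3 to compound 4 cannot be read, as both ends of each are limits.

Benzoyl therefore cannot be ranked against benzyl or 4-methylphenyl. On these data alone, it also remains open whether a 2-chlorophenyl or 2-ethylphenyl group on this nitrogen would give a number like that of compound 2.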